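A few compounds are considered here, and "the series" means these few. Any claim that something is new, unique, unknown or untested is made for them only; others in the source may bear on it.

Measured compounds and their values:
Compound 1, `Oc1cc(C(F)(F)F)ccc1-c1nc(-c2ccccc2O)n(-c2ccc(Br)cc2)n1`, gives 69.4%.
Compound 2, `COc1ccc(-n2nc(-c3ccc(C(F)(F)F)cc3O)nc2-c2ccccc2O)cc1`, gives 69%.
Compound 3, `Oc1cc(C(F)(F)F)ccc1-c1nc(-c2ccccc2O)n(-c2ccc(OC(F)(F)F)cc2)n1`, gives 65.5%.

All three numbers come from a functional assay on PC-12 cells (Rattus norvegicus) for cytotoxicity, read by MTT assay, with stated times of 2 h and 24 h, tested at 1 uM; on this read-out lower numbers stand for a weaker effect and higher numbers for a stronger effect at the one concentration tested. Compound 3 gives the lowest of the three numbers, yet the steps that reach it are a number 3.5 percentage points lower from compound 2 to compound 3 (within the scatter) and a number 3.9 percentage points lower from compound 1 to compound 3 (within the scatter), so on this read-out the three compounds cannot be told apart.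

Compound 4, `Oc1cc(C(F)(F)F)ccc1-c1nc(-c2ccccc2O)n(-c2cccc(C(F)(F)F)c2)n1`, has not been measured. It differs from compound 3 in one place: 3-(trifluoromethyl)phenyl in place of 4-(trifluoromethoxy)phenyl on an aromatic nitrogen.

Two of the measured steps bear on this change, since they also swap the group on the aromatic nitrogen of the shared core: from compound 1 to compound 3 the number moved by a number 3.9 percentage points lower from compound 1 to compound 3 (within the scatter), and from compound 2 to compound 3 by a number 3.5 percentage points lower from compound 2 to compound 3 (within the scatter). Both are within the scatter. The step from compound 1 to compound 2, a number 0.4 percentage points lower from compound 1 to compound 2 (within the scatter), touches the same position and is also within the scatter. The expected step in this assay from compound 3 to compound 4 is therefore a number 1.5 percentage points higher from compound 3 to compound 4 (within the scatter), that is, none beyond the scatter.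

Compound 4 is accordingly estimated to give 67%, with a range from 56% to 78%.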

Compound 4, a percentage reported as activity, at one concentration (the size of the read-out at that concentration, not a potency): 71.5%
Beside the measured number, compound 4's estimate is 4.5 percentage points below it, and the stated range covers the measured number.
By their numbers in this assay, from the lowest: compounds 3, 2, 1 and 4 (each within the scatter of the next).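

Among these compounds, compound 4 brings a 3-(trifluoromethyl)phenyl group onto the aromatic nitrogen, where the earlier compounds carried 4-bromophenyl, 4-methoxyphenyl or 4-(trifluoromethoxy)phenyl, and in this assay the steps are a number 6 percentage points higher from compound 3 to compound 4 (within the scatter) and a number 2.5 percentage points higher from compound 2 to compound 4 (within the scatter) and a number 2.1 percentage points higher from compound 1 to compound 4 (within the scatter). The four compounds therefore cannot be told apart on this read-out, so the position tolerates this change of group, including the move from a substituent named at the 4 position of the phenyl to one named at the 3 position, without a difference beyond the scatter. No measurement is available here that could explain why these numbers stay so close.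

The compounds shown leave open whether a phenyl carrying an amine or a carboxylic acid, or a longer chain in place of the phenyl, would give a number beyond the scatter at this position. They also leave open what happens at the ring atoms bearing the 2-hydroxyphenyl and 2-hydroxy-4-(trifluoromethyl)phenyl groups, which are the same in all four compounds.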